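This account rests on a few compounds, and the source may have more. Where it says the series, first, only, none or still open, it means among the compounds named here.

Measured compounds:
- Compound 1, `CC(C1CC1)n1cc(Nc2nc(N)nc(-c3cccc(-n4ccc5cc(C6CC6)cc(F)c5c4=O)c3CO)n2)cn1`, gives 2000 nM in a physicochemical assay for solubility, read by LC-MS, measured as kinetic solubility, with a stated time of 1 h; on this read-out lower numbers stand for lower solubility and higher numbers for higher solubility.
- Compound 2, `N#Cc1cc(Nc2nc(N)nc(-c3cccc(-n4ccc5cc(C6CC6)cc(F)c5c4=O)c3CO)n2)cn1C1CC1`, gives 4000 nM in this assay.
- Compound 3, `CCn1cc(Nc2nc(N)nc(-c3cccc(-n4ccc5cc(C6CC6)cc(F)c5c4=O)c3CO)n2)cc1C#N`, gives 710 nM in this assay.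

Among these three, compound 3 stands lowest: its number sits under that of compound 1, as a 2.8-fold lower number from compound 1 to compound 3 (0.45 log units; beyond the scatter) shows, and further under that of compound 2, as a 5.6-fold lower number from compound 2 to compound 3 (0.75 log units; beyond the scatter) shows. The step from compound 1 to compound 2 is a 2.0-fold higher number from compound 1 to compound 2 (0.30 log units; within the scatter).

Compound 4, `Nc1nc(Nc2cnn(C3CC3)c2)nc(-c2cccc(-n3ccc4cc(C5CC5)cc(F)c4c3=O)c2CO)n1`, differs from compound 3 in one place: 1-cyclopropyl-1H-pyrazol-4-yl in place of 5-cyano-1-ethyl-1H-pyrrol-3-yl on a nitrogen on an aromatic ring. Two of the measured steps bear on this change. The step from compound 1 to compound 3, which swaps a pyrazolyl group with a cyclopropyl-bearing chain for the cyano-ethyl-pyrrolyl group, ran downward; reversing that direction points upward for compound 4. The step from compound 2 to compound 3, ethyl in place of cyclopropyl, also ran downward, so putting cyclopropyl back points upward again. Compound 4 carries both features that went with the higher numbers, so a modest rise beyond the scatter is expected, a 3.5-fold higher number from compound 3 to compound 4 (0.55 log units; beyond the scatter). Compound 4 is therefore estimated at 2500 nM, in a range from 900 nM to 7000 nM.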

Compound 4, solubility: 4700 nM
For compound 4 the middle estimate is 1.9-fold (0.27 log units) below the measured one; the measured number falls inside the stated range.
By their numbers in this assay, from the lowest: compound 3; then compounds 1, 2 and 4 (each within the scatter of the next, the first and the last beyond it).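

In this assay the swap at this place, on a nitrogen on an aromatic ring, gives a 6.6-fold higher number from compound 3 to compound 4 (0.82 log units; beyond the scatter) and so sets 1-cyclopropyl-1H-pyrazol-4-yl well clear of 5-cyano-1-ethyl-1H-pyrrol-3-yl. With the pyrazolyl ring kept, cyclopropyl in place of 1-cyclopropylethyl gives a 2.4-fold higher number from compound 1 to compound 4 (0.37 log units; beyond the scatter) and shows that the group on the aromatic nitrogen also counts on this ring, as it did on the cyano-pyrrolyl ring. With cyclopropyl kept, changing the ring and losing the nitrile gives a 1.2-fold higher number from compound 2 to compound 4 (0.07 log units; within the scatter) and so, in this one pair, shows no readable difference between the two rings.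

Still open, on these data alone, is how a pyrazolyl ring would read with ethyl, methyl or an amine-bearing chain on its nitrogen, or with a nitrile on the ring. Nothing available explains any of these steps.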